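Hydroxyphenyl isomers and cell toxicity in a small series

The source may report more compounds than this note shows. Statements on the series, on what has been measured and on what is new or still open speak of the compounds shown alone.

The series is read in an ADME assay on HEK293 cells (Homo sapiens) for cytotoxicity, read by CCK-8 assay, with a stated time of 4 days; on this read-out higher numbers stand for weaker inhibition and lower numbers for stronger inhibition. Compound 1 `Oc1ccccc1-c1cc(-c2ccccc2O)nc(-c2ccccc2O)c1` carries three 2-hydroxyphenyl groups and in this assay compound 1 gives 140 nM. Compound 2 `Oc1ccc(-c2cc(-c3cccc(O)c3)cc(-c3ccc(O)cc3)n2)cc1` combines two 4-hydroxyphenyl groups with a 3-hydroxyphenyl group; in this assay compound 2 returns only the limit > 50000 nM. Compound 3 `Oc1ccc(-c2cc(-c3cccc(O)c3)cc(-c3ccccc3O)n2)cc1` holds a 4-hydroxyphenyl, a 3-hydroxyphenyl and a 2-hydroxyphenyl group; in this assay compound 3 likewise returns only the limit > 50000 nM.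

The measured step that the two limits leave unreadable from compound 3 to compound 2 is 4-hydroxyphenyl in place of 2-hydroxyphenyl on an aromatic carbon; its size cannot be read because both ends sit at the limit of > 50000 nM in this assay, at which 2 of the 3 values shown sit. Compound 1 and compound 3 differ in more than one place, and the difference between the two cores is not broken down here.

Compound 4 `Oc1ccc(-c2cc(-c3ccccc3O)nc(-c3ccccc3O)c2)cc1`, not yet measured, arises from compound 1 by 4-hydroxyphenyl in place of 2-hydroxyphenyl on an aromatic carbon. Within the data shown here, this is the same kind of change as the one from compound 3 to compound 2, but the place differs: here it is opposite the ring nitrogen and meta to two 2-hydroxyphenyl groups, whereas there it is next to the ring nitrogen, meta to a 3-hydroxyphenyl group and meta to a 4-hydroxyphenyl group. Since the measured instance yields no readable size, the expected step of a 4.3-fold higher number from compound 1 to compound 4 (0.63 log units; beyond the scatter) rests on compound 1 keeping two 2-hydroxyphenyl groups together with its value 140 nM. The unreadable results of compound 2 and compound 3 mark how far the number could drift. Compound 4 is expected to give about 600 nM, within roughly 140 nM to 10000 nM.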

Compound 4, half-maximal inhibitory concentration: > 50000 nM
Compound 4 was reported as a limit; the forecaster's own chance of this, stated with the estimate: 20%; middle value at least 83-fold (1.92 log units) from the limit.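

Set opposite the ring nitrogen, 4-hydroxyphenyl in place of 2-hydroxyphenyl gives an at least 350-fold higher number from compound 1 to compound 4 (2.55 log units; beyond the scatter) in this assay, the only readable size for this change in the series. Compound 4 gives > 50000 nM, which is a limit of the assay and not a number, so the step has a lower bound only. The same kind of change from compound 3 to compound 2 cannot be read, with both compounds at the limit, so the series does not show whether the size of the change carries from one core to another: the limit of > 50000 nM in this assay, at which 3 of the 4 values shown sit.

Among these compounds, compound 1, with three 2-hydroxyphenyl groups, gives 140 nM as the only number, which leaves open whether a compound with a different arrangement of hydroxyphenyl groups would also give a number rather than a limit, and how much each 2-hydroxyphenyl group contributes to that value. Also open, as far as these compounds go, is how the core of compound 1 would read with a group other than hydroxyphenyl opposite the ring nitrogen, such as an aminophenyl group or a phenyl ring bearing a carboxylic acid.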